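The source may report more compounds than this note shows. Statements on the series, on what has been measured and on what is new or still open speak of the compounds shown alone.

Compound 1 `C=C[C@@](C)(/C=C/c1ccc(O)c(/C=C/C(=O)c2ccccc2)c1)CCC=C(C)C` gives > 7410 nM in an ADME assay on HEK293 cells (Homo sapiens) for cytotoxicity, with a stated time of 72 h (a higher number here means that more compound is needed for the effect, a lower number that less compound is needed), and this is a limit, not a number. Compound 2 `C=C[C@@](C)(/C=C/c1ccc(O)c(/C=C/C(=O)OCC)c1)CCC=C(C)C` gives > 36600 nM in this assay and this is also a limit. Compound 3 `C=C[C@@](C)(/C=C/c1ccc(O)c(/C=C/C(=O)OCc2ccccc2)c1)CCC=C(C)C` stands at > 36600 nM in this assay and that too is only a limit. For the measured compounds named here, no compound has a number yet, so the place of compound 3 can be told no more closely.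

Amino in place of benzyloxy on a carbonyl carbon leads from compound 3 to compound 4 `C=C[C@@](C)(/C=C/c1ccc(O)c(/C=C/C(N)=O)c1)CCC=C(C)C` with the counted change amino in place of benzyloxy on a carbonyl carbon as its full description. The measured changes on that carbonyl carbon are a step that the two limits leave unreadable from compound 1 to compound 2 and a step that the two limits leave unreadable from compound 1 to compound 3 and the remaining measured step is a step that the two limits leave unreadable from compound 2 to compound 3 and none of the three has a readable size. No size carries over, so no step beyond the scatter is expected in this assay in either direction, and another limit is the likely report. The estimated step is a number no higher from compound 3 to compound 4 (the limit leaves the size open) and it remains only an expectation. For compound 4 the expected value is 36600 nM with an estimated range from 15000 nM to 80000 nM in this assay for now.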

Compound 4, half-maximal effective concentration: > 36600 nM
Compound 4: a limit, no number; the forecaster's own chance of this, stated with the estimate: 85%; the middle value lies on the limit itself.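

Compound 4 gives > 36600 nM in this assay, a limit and not a number. The steps to compound 4 from compound 1, compound 2 and compound 3 cannot be read. The compounds shown leave open what concentration any of them needs for the effect, and the values stop at limits: the limit of > 36600 nM in this assay, at which 3 of the 4 values shown sit.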